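From isopentyloxy to isobutoxy: compound 2 to compound 4

A few compounds are considered here, and "the series" means these few. Any claim that something is new, unique, unknown or untested is made for them only; others in the source may bear on it.

Three compounds have so far been measured in a functional assay on PC-3 cells (Homo sapiens) for antiproliferative activity, read by sulforhodamine B assay, with a stated time of 3 days; on this read-out lower numbers stand for an effect already at smaller amounts and higher numbers for an effect only at larger amounts of compound:

compound 1 `CCCC1=C(OC)C(CCC)(CCC)C(=O)/C(=C(O)\C=C\c2ccccc2)C1=O`: 8.2 uM
compound 2 `CCCC1=C(OCCC(C)C)C(CCC)(CCC)C(=O)/C(=C(O)\C=C\c2ccccc2)C1=O`: 17 uM
compound 3 `COC1=C(CC(C)C)C(=O)/C(=C(O)/C=C/c2ccccc2)C(=O)C1(CC(C)C)CC(C)C`: 12.4 uM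

Among these, compound 2 gives the highest of the three numbers in this assay. Compound 3 is the nearest to it, and the two lie within the scatter of each other. Compound 1 is the furthest from compound 2, with a lower number that lies beyond the scatter. Only one measured step joins two of these compounds that differ in a single place: a 2.1-fold higher number from compound 1 to compound 2 (0.32 log units; beyond the scatter), a modest step.

Compound 4 `CCCC1=C(OCC(C)C)C(CCC)(CCC)C(=O)/C(=C(O)\C=C\c2ccccc2)C1=O` has not yet been measured. It differs from compound 2 by isopropyl in place of isobutyl on a saturated chain carbon bound to an oxygen on an unsaturated carbon. For the measured compounds named here, this change touches the same place as the one measured step, and it takes away part of what that step added, so compound 4 stands partway back toward compound 1. On that basis a small step toward a lower number is expected in this assay, one that may well remain within the scatter, and the expected step is a 1.4-fold lower number from compound 2 to compound 4 (0.15 log units; within the scatter). Compound 4 is estimated to give 12 uM in this assay, with a range from 6 uM to 25 uM.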

Compound 4, concentration for half-maximal effect: 12.2 uM
Estimate against measurement, compound 4: 1.0-fold (0.01 log units) below, within the range that was stated.
By their numbers in this assay, from the lowest: compounds 1, 4, 3 and 2 (each within the scatter of the next, the first and the last beyond it).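

In this assay the isobutoxy ether sits within the scatter on both sides, with a 1.4-fold lower number from compound 2 to compound 4 (0.14 log units; within the scatter) on one side and a 1.5-fold higher number from compound 1 to compound 4 (0.17 log units; within the scatter) on the other. For the compounds shown here, the only step beyond the scatter at this place, a 2.1-fold higher number from compound 1 to compound 2 (0.32 log units; beyond the scatter) in the earlier data, therefore now divides into two steps that each lie within it, so that only the two ends of this short series can be told apart. The isopropyl-for-isobutyl change on the saturated chain carbon bound to the oxygen thus gives no separable difference on its own, and nothing available offers an explanation for these numbers.

The compounds shown leave open whether a chain longer than isopentyl at this place, or an amine or a carboxylic acid carried at the end of the chain, would take the number beyond the scatter of compound 2 in this assay in either direction. They also leave open whether isobutoxy or isopentyloxy on the core of compound 3, with its isobutyl chains, would give steps of the same size as those seen here.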